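Phenyl for Pentyl on the Urea Nitrogen

A few compounds are considered here, and "the series" means these few. Any claim that something is new, unique, unknown or untested is made for them only; others in the source may bear on it.

Compound 1 `CCCCCNC(=O)/N=C(\N)NCCCc1sc(N)nc1C`: 4.47 nM
Compound 2 `Cc1nc(N)sc1CCCN/C(N)=N/C(=O)NC(C)c1ccc(OC(F)(F)F)cc1`: 126 nM

Of the compounds shown here, two have been measured in an assay on membranes from Sf9 cells for displacement of a labelled ligand from histamine H2 receptor (Homo sapiens), read by scintillation counting, with a stated time of 60 min; on this read-out higher numbers stand for weaker inhibition and lower numbers for stronger inhibition. Compound 1 gives 4.47 nM, the lowest of the two numbers; compound 2 gives 126 nM, a gap from compound 1 that lies beyond the usual scatter. Compound 3 `Cc1nc(N)sc1CCCN/C(N)=N/C(=O)Nc1ccccc1` has not yet been measured. It differs from compound 1 in one place: phenyl in place of pentyl on an amide-type nitrogen. For the measured compounds named here, no step between two measured compounds isolates this change, so its size must be judged from compound 1 and from what compound 2 shows. Compound 2, whose group on the amide-type nitrogen also contains a six-membered aromatic ring, stands far weaker than compound 1, though it differs in more than one place. A loss is expected for compound 3, beyond the scatter yet smaller than the gap to compound 2. For compound 3 the estimated step is a 3.4-fold higher number from compound 1 to compound 3 (0.53 log units; beyond the scatter). Compound 3 is expected to give 15 nM, within 5 nM to 50 nM.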

Compound 3, inhibition constant: 3160 nM
Compound 3: middle estimate off by 210-fold (2.32 log units), on the low side; the whole stated range lies below it.
By their numbers in this assay, from the lowest: compound 1; then compound 2; then compound 3.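

Placing phenyl instead of pentyl on the amide-type nitrogen costs a great deal of affinity in this assay, with a 710-fold higher number from compound 1 to compound 3 (2.85 log units; beyond the scatter), and this is the first step that isolates a change at this position. The entering and leaving groups differ by a single heavy atom, and neither carries hydrogen-bond donors, hydrogen-bond acceptors or a net charge, yet the read-out still moves far beyond the scatter, so these counts do not predict what this position tolerates. Nothing measured here gives a reason for the loss.

The compounds shown leave open whether the loss goes with the aromatic ring itself or with the removal of the open chain. A cyclohexyl or benzyl group on the same nitrogen would help to separate these two readings.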